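Bis-enone series: fluorophenyl for dimethoxyphenyl on A549 growth

This account rests on a few compounds, and the source may have more. Where it says the series, first, only, none or still open, it means among the compounds named here.

Measured compounds, growth inhibition of A549 cells:
compound 1, `COc1ccc(/C=C/C(=O)C(=Cc2cccc(F)c2)C(=O)/C=C/c2ccc(OC)c(OC)c2)cc1OC`: 580 nM
compound 2, `COc1ccc(C=C(C(=O)/C=C/c2ccc(OC)c(OC)c2)C(=O)/C=C/c2ccc(OC)c(OC)c2)c(OC)c1`: 650 nM
compound 3, `COc1ccc(C=C(C(=O)/C=C/c2ccc(O)c(OC)c2)C(=O)/C=C/c2ccc(O)c(OC)c2)c(OC)c1`: 690 nM

All three were read in a functional assay on A549 cells (Homo sapiens) for inhibition, read by sulforhodamine B assay, with a stated time of 48 h; a higher number here means a weaker inhibitor of growth, a lower number a stronger inhibitor of growth. Compound 1 gives 580 nM, compound 2 gives 650 nM and compound 3 gives 690 nM; the three numbers lie within the scatter of one another, so no order among them is claimed.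

Compound 2 and compound 1 differ by 3-fluorophenyl in place of 2,4-dimethoxyphenyl on a double-bonded chain carbon bound to a double-bonded chain carbon. That step is a 1.1-fold lower number from compound 2 to compound 1 (0.05 log units; within the scatter). How the core of compound 2 differs from the core of compound 3 is not broken down here.

Compound 4, `COc1cc(/C=C/C(=O)C(=Cc2cccc(F)c2)C(=O)/C=C/c2ccc(O)c(OC)c2)ccc1O`, is not yet measured in this assay. It differs from compound 3 by 3-fluorophenyl in place of 2,4-dimethoxyphenyl on a double-bonded chain carbon bound to a double-bonded chain carbon, the same change at the same place as between compound 2 and compound 1.

Because the earlier step was a 1.1-fold lower number from compound 2 to compound 1 (0.05 log units; within the scatter), a similarly small step is expected from compound 3 to compound 4, namely a 1.1-fold lower number from compound 3 to compound 4 (0.05 log units; within the scatter). Compound 4 is therefore estimated at 620 nM in this assay, with a likely range from 300 nM to 1300 nM.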

Compound 4, concentration for 50% growth inhibition: 360 nM
Compound 4: middle estimate off by 1.7-fold (0.24 log units), on the high side; the range from low to high includes it.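

In this assay, 3-fluorophenyl in place of 2,4-dimethoxyphenyl gives a 1.9-fold lower number from compound 3 to compound 4 (0.28 log units; within the scatter). Set beside the earlier step, the change carries over the two cores with no difference that can be read between the sizes of the steps: the same change on two cores in this assay, a 1.1-fold lower number (0.05 log units; within the scatter) from compound 2 to compound 1 and a 1.9-fold lower number (0.28 log units; within the scatter) from compound 3 to compound 4, 1.7-fold (0.23 log units) apart, within the scatter of two such steps. This shows that the two steps agree within the scatter on these two cores; it does not show that the change shifts growth inhibition on either core, or that it would behave alike on a further core.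

The compounds shown leave open how a phenyl carrying an amine or a carboxylic acid would read at this place, on a double-bonded chain carbon bound to a double-bonded chain carbon.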